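Replacing an aminopyridine that abolished activity with a cyanophenyl

The compounds below may be only part of what the source reports. "The series", "measured", "known", "first", "only" and "open" are said of these compounds alone.

Measured compounds:
compound 1 `O=C(O)Cc1sc(C(c2ccc(F)cc2)c2ccc(F)cc2)nc1-c1cc(F)cc(F)c1`: 340 nM
compound 2 `O=C(O)Cc1sc(C(c2ccc(F)cc2)c2ccc(F)cc2)nc1-c1ccco1`: 140 nM
compound 3 `Cc1cc(-c2nc(C(c3ccc(F)cc3)c3ccc(F)cc3)sc2CC(=O)O)cnc1N`: > 100000 nM

All three compounds share one core and were tested in an in vitro functional assay on HEK285-7 cells for antagonist activity at prostaglandin D2 receptor 2 (Homo sapiens), read by BRET and beta-arrestin recruitment; on this read-out higher numbers stand for weaker inhibition and lower numbers for stronger inhibition. Compound 1 gives 340 nM and compound 2 gives 140 nM, and the change from one to the other is a 2.4-fold lower number from compound 1 to compound 2 (0.39 log units; beyond the scatter). For compound 3 the assay returns only a limit, > 100000 nM, so no number is known for it. It thus sits at the bottom of the three: the change is an at least 290-fold higher number from compound 1 to compound 3 (2.46 log units; beyond the scatter) and an at least 710-fold higher number from compound 2 to compound 3 (2.85 log units; beyond the scatter). In this assay (the limit of > 100000 nM in this assay, at which 1 of the 3 values shown sits).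

Compound 4 `N#Cc1ccc(-c2nc(C(c3ccc(F)cc3)c3ccc(F)cc3)sc2CC(=O)O)cc1` is not yet measured. It differs from compound 3 in one place: 4-cyanophenyl in place of 6-amino-5-methylpyridin-3-yl on an aromatic carbon. Going by the values given here, the steps that bear on this are the two that put the 6-amino-5-methylpyridin-3-yl in place of a ring without that group, each of which was large and went toward weaker inhibition. Removing it again in favour of 4-cyanophenyl, a carbon-only ring as in compound 1, is therefore expected to reverse most of that loss, giving a large step in the other direction, an at least 160-fold lower number from compound 3 to compound 4 (2.22 log units; beyond the scatter). Compound 4 is estimated at 600 nM, within the range 100 nM to 6000 nM.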

Compound 4, half-maximal inhibitory concentration: 1500 nM
The estimate for compound 4 lay 2.5-fold (0.40 log units) below the measured number; the range from low to high includes it.
By their numbers in this assay, from the lowest: compound 2; then compound 1; then compound 4. At a limit, above all of these: compound 3.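

In this assay, compound 4 shows that a six-membered aromatic ring at this place, next to the ring nitrogen, does not by itself abolish inhibition, since the 4-cyanophenyl brings back a measurable value (an at least 66-fold lower number from compound 3 to compound 4 (1.82 log units; beyond the scatter)). Compound 3 stands at a limit of the assay and not at a number, so that step is only a bound: the limit of > 100000 nM in this assay, at which 1 of the 4 values shown sits. The recovery is also partial, and the position proves sensitive to which ring it carries, with the 4-cyanophenyl weaker than both the 3,5-difluorophenyl (a 4.4-fold higher number from compound 1 to compound 4 (0.64 log units; beyond the scatter)) and the furan-2-yl (an 11-fold higher number from compound 2 to compound 4 (1.03 log units; beyond the scatter)).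

The compounds shown leave open which part of the 6-amino-5-methylpyridin-3-yl goes with the loss, the amine, the methyl or the ring nitrogen, as all three leave together in this change. They also leave open whether the gap to compound 1 follows the nitrile itself or its place on the ring, and whether a methoxy group or a single fluorine in its stead would give a value closer to that of compound 1.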